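The compounds below may be only part of what the source reports. "The series", "measured", "known", "first", "only" and "open" are said of these compounds alone.

Measured in a functional assay on HCT-116 cells (Homo sapiens) for cytotoxicity, read by MTT assay, with a stated time of 5 days; on this read-out higher numbers stand for weaker inhibition and lower numbers for stronger inhibition:
- compound 1 `CCOc1cc(C(C)(C)C)ccc1C1=N[C@@](C)(c2ccc(Cl)cc2)[C@@](C)(c2ccc(Cl)cc2)N1C(=O)N1CCN(CCC(F)(F)F)CC1`: 1300 nM
- compound 2 `CCOc1cc(C(C)(C)C)ccc1C1=N[C@@](C)(c2ccc(Cl)cc2)[C@@](C)(c2ccc(Cl)cc2)N1C(=O)N1CCN(CCNS(C)(=O)=O)CC1`: 900 nM
- compound 3 `CCOc1cc(C(C)(C)C)ccc1C1=N[C@@](C)(c2ccc(Cl)cc2)[C@@](C)(c2ccc(Cl)cc2)N1C(=O)N1CCN(CCNC(C)=O)CC1`: 500 nM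

Compound 3, at 500 nM, stands clear of only one of the other two compounds: a 2.6-fold lower number from compound 1 to compound 3 (0.41 log units; beyond the scatter). Against the other, the gap is smaller: a 1.8-fold lower number from compound 2 to compound 3 (0.26 log units; within the scatter).

The next step leads to compound 4 `CCOc1cc(C(C)(C)C)ccc1C1=N[C@@](C)(c2ccc(Cl)cc2)[C@@](C)(c2ccc(Cl)cc2)N1C(=O)N1CCN(CC(=O)N2CCCC2)CC1`: (pyrrolidin-1-yl)carbonyl in place of acetamidomethyl on a saturated chain carbon bound to an amine nitrogen in a ring. In words, (pyrrolidin-1-yl)carbonyl comes in place of acetamidomethyl on a saturated chain carbon bound to an amine nitrogen in a ring. Cut one bond further out, this reads 2-acetamidoethyl to ((pyrrolidin-1-yl)carbonyl)methyl.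

The measured steps that bear on this all change the end of the same chain. The remaining one is a 1.4-fold lower number from compound 1 to compound 2 (0.16 log units; within the scatter). Among the compounds with values here, the largest of them, from compound 1 to compound 3, is only modest, and none of the measured compounds tests (pyrrolidin-1-yl)carbonyl directly. In this assay, a large step is therefore not expected. The direction is weakly expected to be back toward the values of compound 1 and compound 2, and a result within the scatter of compound 3 would fit equally well.

The expected change is a 1.4-fold higher number from compound 3 to compound 4 (0.15 log units; within the scatter).

Compound 4 is estimated at 700 nM, with an expected range of 300 nM to 1600 nM.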

Compound 4, half-maximal inhibitory concentration: 700 nM
For compound 4 middle estimate and measured number coincide at the digits printed; low and high end bracket the measured number.
By their numbers in this assay, from the lowest: compounds 3, 4, 2 and 1 (each within the scatter of the next, the first and the last beyond it).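

Setting (pyrrolidin-1-yl)carbonyl in place of acetamidomethyl on a saturated chain carbon bound to an amine nitrogen in a ring gives, in this assay, a 1.4-fold higher number from compound 3 to compound 4 (0.15 log units; within the scatter), so this position takes up a five-membered non-aromatic ring with no step beyond the scatter. Within the data shown here, the other two comparisons also stay within the scatter, with a 1.3-fold lower number from compound 2 to compound 4 (0.11 log units; within the scatter) and a 1.9-fold lower number from compound 1 to compound 4 (0.27 log units; within the scatter), which places compound 4 among the earlier compounds without separating it from any of them. Among these compounds, the entering group has no hydrogen-bond donor where acetamidomethyl has one, yet compound 4 stays within the scatter of compound 3, so the one step in this set beyond the scatter, a 2.6-fold lower number from compound 1 to compound 3 (0.41 log units; beyond the scatter), cannot be read as a need for the amide hydrogen.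

No measurement at hand accounts for these numbers. From the compounds shown here alone, it remains open whether a free amine, a carboxylic acid or a longer chain at this position would give a step beyond the scatter from compound 3, in either direction, in this assay.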